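A Phenylethenyl Arm Replaces a Dimethylaminophenyl Arm

The source may hold more compounds than are shown below. What is called first, only, known or untested is meant among the compounds shown, and "the series" means these compounds.

Of the compounds shown here, three built on one shared core have been tested for their power to stop human breast cancer cells from multiplying. Compound 1 `CO[C@@H]1[C@@H](O)[C@@H](O)[C@H](Oc2ccc3c(c2C)OC(=O)C(n2cc(-c4ccc(F)cc4F)nn2)C3)OC1(C)C` carries a 2,4-difluorophenyl group on its triazole. In a functional assay on MCF7 cells (Homo sapiens) for antiproliferative activity (a lower number here means a stronger inhibitor, a higher number a weaker inhibitor), compound 1 gives > 100000 nM, which is a limit of the assay rather than a number. Compound 2 `COc1ccc(-c2cn(C3Cc4ccc(O[C@@H]5OC(C)(C)[C@H](OC)[C@@H](O)[C@H]5O)c(C)c4OC3=O)nn2)cc1` carries a 4-methoxyphenyl group in the same place. In this assay compound 2 gives > 100000 nM, again a limit. Compound 3 `CO[C@@H]1[C@@H](O)[C@@H](O)[C@H](Oc2ccc3c(c2C)OC(=O)C(n2cc(-c4ccc(N(C)C)cc4)nn2)C3)OC1(C)C` carries a 4-(dimethylamino)phenyl group. In this assay compound 3 gives > 100000 nM, also a limit. Because all three values sit at the limit of > 100000 nM in this assay, at which 3 of the 3 values shown sit, the steps a step that the two limits leave unreadable from compound 1 to compound 2, a step that the two limits leave unreadable from compound 1 to compound 3 and a step that the two limits leave unreadable from compound 2 to compound 3 cannot be sized, and compound 3 cannot be ranked against its two companions.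

Compound 4 `CO[C@@H]1[C@@H](O)[C@@H](O)[C@H](Oc2ccc3c(c2C)OC(=O)C(n2cc(/C=C/c4ccccc4)nn2)C3)OC1(C)C` differs from compound 3 in one place: 2-phenylethenyl in place of 4-(dimethylamino)phenyl on an aromatic carbon. The three measured steps bear on this change only in showing that swapping one aryl group for another has not yet pulled any compound into the measurable range. The step that the limit leaves unreadable from compound 3 to compound 4 is therefore expected to be small or unreadable. Compound 4 is estimated at 150000 nM, with a range from 30000 nM to 1000000 nM.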

Compound 4, half-maximal inhibitory concentration: 14600 nM
For compound 4 the middle estimate is 10-fold (1.01 log units) above the measured one; measured number outside the range, below it.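

At this place on the five-membered aromatic ring with 3 nitrogen, 2-phenylethenyl, a group with 1 double bond outside aromatic rings, brings the series into the readable range of this assay, which 2,4-difluorophenyl, 4-methoxyphenyl and 4-(dimethylamino)phenyl did not do. The change gives an at least 6.8-fold lower number from compound 3 to compound 4 (0.83 log units; beyond the scatter), and it likewise gives an at least 6.8-fold lower number from compound 2 to compound 4 (0.83 log units; beyond the scatter) and an at least 6.8-fold lower number from compound 1 to compound 4 (0.83 log units; beyond the scatter), so all three steps lie beyond the usual scatter of repeated measurements. Each size is only a floor, and the true gaps could be larger, as the three earlier compounds stand at a limit of the assay and not at a number: the limit of > 100000 nM in this assay, at which 3 of the 4 values shown sit.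

The compounds shown do not separate the double bond from the phenyl ring, so it remains open whether 2-phenylethyl, with a saturated chain in place of the double bond, would behave like 2-phenylethenyl. As far as these compounds go, it also remains open how an amine or a methoxy group on the phenyl ring of 2-phenylethenyl would shift the number in this assay.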